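The source may hold more compounds than are shown below. What is called first, only, known or untested is meant among the compounds shown, and "the series" means these compounds.

Measured so far:
- compound 1 `COc1cc(/C=C/C(=O)c2cccc(NC(=O)C(C)C)c2)ccc1O`: 8.31 ug/mL
- compound 2 `COC(=O)C(=O)Nc1cccc(C(=O)/C=C/c2ccc(O)c(OC)c2)c1`: 12.2 ug/mL
- compound 3 `CCCC(=O)Nc1cccc(C(=O)/C=C/c2ccc(O)c(OC)c2)c1`: 5.56 ug/mL

All three share one core and differ only in the group on the amide carbonyl carbon. In a functional assay on U-87MG ATCC cells (Homo sapiens) for inhibition (on this read-out lower numbers stand for stronger inhibition and higher numbers for weaker inhibition), compound 3 gives 5.56 ug/mL, the lowest of the three numbers; its gap to compound 1 lies within the scatter (a 1.5-fold lower number from compound 1 to compound 3 (0.17 log units; within the scatter)), while the step to compound 2 is a modest one beyond it (a 2.2-fold lower number from compound 2 to compound 3 (0.34 log units; beyond the scatter)).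

Compound 4 `COc1cc(/C=C/C(=O)c2cccc(NC(=O)c3ccc(Cl)cc3)c2)ccc1O` takes the next step from compound 3: 4-chlorophenyl in place of propyl on a carbonyl carbon. Among the compounds with values here, no measured step so far exchanges an alkyl group for an aromatic one at this carbonyl carbon; the steps in hand (a 1.5-fold higher number from compound 1 to compound 2 (0.17 log units; within the scatter), a 1.5-fold lower number from compound 1 to compound 3 (0.17 log units; within the scatter), a 2.2-fold lower number from compound 2 to compound 3 (0.34 log units; beyond the scatter)) show that small changes at this position move this assay by little, at most modestly. On that basis a step of at most modest size is expected for compound 4, with direction uncertain: a 1.2-fold lower number from compound 3 to compound 4 (0.09 log units; within the scatter). Compound 4 is therefore estimated at 4.5 ug/mL, with a range from 2 ug/mL to 10 ug/mL.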

Compound 4, half-maximal inhibitory concentration: > 50 ug/mL
Compound 4: no number, only a limit (the forecaster's own chance of this, stated with the estimate: 5%); at least 11-fold (1.04 log units) between middle value and limit.
By their numbers in this assay, from the lowest: compounds 3, 1 and 2 (each within the scatter of the next, the first and the last beyond it). At a limit, above all of these: compound 4.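

In this assay, within the data shown here, this carbonyl carbon proves far less forgiving than the earlier compounds suggested, since 4-chlorophenyl in place of the three smaller groups gives clear jumps (an at least 8.9-fold higher number from compound 3 to compound 4 (0.95 log units; beyond the scatter); an at least 6.0-fold higher number from compound 1 to compound 4 (0.77 log units; beyond the scatter); an at least 4.0-fold higher number from compound 2 to compound 4 (0.61 log units; beyond the scatter)). All three steps lie beyond the scatter, whereas exchanges among propyl, isopropyl and methoxycarbonyl stayed within it or were modest, so the position is not indifferent to the group it carries. As far as these compounds go, the full size of these steps stays unknown, for compound 4 has only a limit and not a number: the limit of > 50 ug/mL in this assay, at which 1 of the 4 values shown sits.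

From the compounds shown here alone, whether the ring or the chlorine drives the change stays open, as a plain phenyl or a benzyl group at this carbon would separate the two. A longer chain such as hexyl, or a chain ending in an amine or a carboxylic acid, also remains untested among the compounds shown.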